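Taking the bromo off compound 3 under the assay limit

The source may hold more compounds than are shown below. What is called first, only, known or untested is meant among the compounds shown, and "the series" means these compounds.

In an ADME assay on MT4 cells (Homo sapiens) for cytotoxicity, read by MTT assay, with a stated time of 96 h (on this read-out lower numbers stand for higher toxicity in this test and higher numbers for lower toxicity in this test), compound 3 (`Brc1ccc(NCc2cn(-c3ccccc3)nc2-c2ccc(Br)cc2)cc1`) gives > 100000 nM as a limit, so it has no exact place in the series. Compound 1 (`FC(F)(F)c1ccc(NCc2cn(-c3ccccc3)nc2-c2ccc(Br)cc2)cc1`) gives > 100000 nM as a limit too. Compound 2 (`Cc1ccc(-c2nn(-c3ccccc3)cc2CNc2ccccc2)cc1`), which carries an anilinomethyl group, gives > 100000 nM as a limit as well. For the measured compounds named here, the series so far reads flat, with the limit of > 100000 nM in this assay, at which 3 of the 3 values shown sit, as the whole of the evidence.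

The next entry is compound 4 (`Brc1ccc(-c2nn(-c3ccccc3)cc2CNc2ccccc2)cc1`), which has hydrogen in place of bromo on an aromatic carbon of compound 3, para to a large group, so that (4-bromophenyl)amino becomes anilino (counted: hydrogen in place of bromo on an aromatic carbon). Going by the values given here, the only measured step that bears on this is a step that the two limits leave unreadable from compound 1 to compound 3 with bromo in place of trifluoromethyl, and it offers no size to carry over. Among the compounds with values here, with every compound so far on the same limit, no step beyond the scatter is expected in this assay and no direction can be given. The expected outcome is a number no higher from compound 3 to compound 4 (the limit leaves the size open) in this estimate. A further report as a limit is the most likely result. For compound 4 the estimated value is 100000 nM with an expected range of 40000 nM to 100000 nM on this read-out.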

Compound 4, half-maximal cytotoxic concentration: > 100000 nM
Compound 4 ended at the assay's limit; the forecaster's own chance of this, stated with the estimate: 80%; the middle value lies on the limit itself.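

Compound 4, like compound 1, compound 2 and compound 3, gives only a limit in this assay, so no step among these four compounds can be read: the limit of > 100000 nM in this assay, at which 4 of the 4 values shown sit.

The compounds shown leave open whether bromo, methyl, trifluoromethyl or hydrogen on the aromatic carbon makes any difference to this read-out, with no exact value among them.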